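Propanoyl to propyl on the shared core

The compounds below may be only part of what the source reports. "The series", "measured", "known", "first", "only" and "open" are said of these compounds alone.

Measured so far in a functional assay on DLD-1 cells (Homo sapiens) for cytotoxicity, with a stated time of 48 h; on this read-out lower numbers stand for stronger inhibition and higher numbers for weaker inhibition
compound 1 `CCOc1ccc2oc(/C=C/[S+](C)[O-])cc(=O)c2c1` at 4900 nM
compound 2 `CC(C)CCOc1ccc2oc(/C=C/[S+](C)[O-])cc(=O)c2c1` at 4100 nM
compound 3 `CCC(=O)Oc1ccc2oc(/C=C/[S+](C)[O-])cc(=O)c2c1` at 9000 nM

Compound 3 stands at 9000 nM on these numbers. The step of a 1.8-fold higher number from compound 1 to compound 3 (0.26 log units; within the scatter) stays within the scatter, and the step of a 2.2-fold higher number from compound 2 to compound 3 (0.34 log units; beyond the scatter) goes just beyond it.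

Among the compounds with values here, compound 4 `CCCOc1ccc2oc(/C=C/[S+](C)[O-])cc(=O)c2c1` carries propyl in place of propanoyl on an oxygen on an aromatic ring as its one change. Those two steps bear on it in reverse, since each puts propanoyl where compound 1 has ethyl or compound 2 has isopentyl. Within the data shown here, the step of a 1.2-fold lower number from compound 1 to compound 2 (0.08 log units; within the scatter) adds that these two chains give no separation in this assay so far. Among the measured compounds shown here, no propyl compound has been measured yet.

The expected step is a 2.0-fold lower number from compound 3 to compound 4 (0.30 log units; within the scatter) toward a lower number, about the size of those two steps and near the edge of the scatter. The estimate for compound 4 is 4500 nM with an expected range of 2500 nM to 8000 nM until a measurement is available.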

Compound 4, half-maximal inhibitory concentration: 6200 nM
For compound 4 the middle estimate is 1.4-fold (0.14 log units) below the measured one; the measured number falls inside the stated range.
By their numbers in this assay, from the lowest: compounds 2, 1, 4 and 3 (each within the scatter of the next, the first and the last beyond it).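

In this assay, the step of a 1.5-fold lower number from compound 3 to compound 4 (0.16 log units; within the scatter) shows that replacing propanoyl with propyl on this oxygen, which removes the carbonyl, gives no separation that clears the scatter. Propyl also falls in with the other two ether chains, as the steps of a 1.3-fold higher number from compound 1 to compound 4 (0.10 log units; within the scatter) and a 1.5-fold higher number from compound 2 to compound 4 (0.18 log units; within the scatter) both stay within the scatter, so ethyl, propyl and isopentyl are not told apart at this position. Within the data shown here, the only step here beyond the scatter remains a 2.2-fold higher number from compound 2 to compound 3 (0.34 log units; beyond the scatter) and it comes close to the edge, so with compound 4 showing no such separation, the ester against ether contrast is not supported as a general pattern.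

As far as these compounds go, whether an amine on the chain, a carboxylic acid at its end or a chain longer than isopentyl would shift the number clearly at this position stays open. No measurement at hand gives a reason for the size of these steps.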